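A few compounds are considered here, and "the series" means these few. Any claim that something is new, unique, unknown or untested is made for them only; others in the source may bear on it.

Compounds measured so far:
compound 1 `CC1(C)[C@@H]2CC3=N[C@@H](CCC(=O)O)C(=O)O[C@@]3(C)[C@H]1C2` gives 42000 nM in a functional assay on PC-3 cells (Homo sapiens) for antiproliferative activity, read by sulforhodamine B assay, with a stated time of 48 h; on this read-out higher numbers stand for weaker inhibition and lower numbers for stronger inhibition;
compound 2 `CC(C)(C)OC(=O)NCCCC[C@@H]1N=C2C[C@@H]3C[C@@H](C3(C)C)[C@]2(C)OC1=O` gives 18000 nM in this assay;
compound 3 `CC1(C)[C@H]2CC3=N[C@H](CCC(=O)O)C(=O)O[C@]3(C)[C@@H]1C2` gives 38000 nM in this assay.

Compound 1 stands at the highest number of the three, and so at the weakest end of the range seen here. Its nearest neighbour is compound 3, reached by the step of a 1.1-fold lower number from compound 1 to compound 3 (0.04 log units; within the scatter); the two compounds are mirror images of one another (the fact that compounds 1 and 3 differ only in the configuration as drawn), and their numbers cannot be told apart. Compound 2 carries a different side chain at the same position and a different configuration, and its number sits lower than that of compound 1, but as two changes are made at once no single step can be read from that pair.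

Compound 4 `CC1(C)[C@@H]2CC3=NCC(=O)O[C@@]3(C)[C@H]1C2` arises from compound 1 by the change (hydrogen in place of 2-carboxyethyl on a saturated ring carbon). Going by the values given here, no measured step removes this side chain, so the only step bearing on the position is the stereochemical one, which was within the scatter. The step from compound 1 to compound 4 is therefore expected to be small, a 1.1-fold lower number from compound 1 to compound 4 (0.02 log units; within the scatter), with no direction beyond the scatter. Compound 4 is accordingly estimated at 40000 nM, in the range 15000 nM to 110000 nM.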

Compound 4, half-maximal inhibitory concentration: 43000 nM
For compound 4 the middle estimate is 1.1-fold (0.03 log units) below the measured one; measured number inside the range.
By their numbers in this assay, from the lowest: compound 2; then compounds 3, 1 and 4 (each within the scatter of the next).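

In this assay, replacing the 2-carboxyethyl chain with hydrogen on the saturated ring carbon next to the ring nitrogen gives a 1.0-fold higher number from compound 1 to compound 4 (0.01 log units; within the scatter), so the two compounds cannot be told apart. Going by these compounds alone, this is the first direct look at what the chain itself contributes, and in this read-out, the chain and its carboxylic acid can be removed entirely with no detectable effect on the number. Until now, the only readable comparison involving this position was a change of configuration, a different kind of change that also left the numbers indistinguishable: the fact that compounds 1 and 3 differ only in the configuration as drawn

As far as these compounds go, it remains open whether any group on this carbon can shift the number beyond the scatter, and a free primary amine, a methyl group or a phenyl ring there could each be compared directly with compound 4. Within the data shown here, compound 2 does not settle this, since it differs from compound 4 in more than one place and so gives no clean step.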